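A few compounds are considered here, and "the series" means these few. Any claim that something is new, unique, unknown or untested is made for them only; others in the source may bear on it.

Measured so far:
compound 1 `Cc1cnc(Nc2ccc(S(C)(=O)=O)cc2)nc1Nc1nc2ccc(Cl)cc2s1`, 4180 nM;
compound 2 `CS(=O)(=O)c1ccc(Nc2ncc(F)c(Nc3nc4ccc(Cl)cc4s3)n2)cc1`, > 50000 nM;
compound 3 `NS(=O)(=O)c1ccc(Nc2nccc(Nc3nc4ccc(F)cc4s3)n2)cc1`, 450 nM.

In a functional assay on HeLa cells (Homo sapiens) for antiproliferative activity, read by MTT assay, with a stated time of 48 h (on this read-out higher numbers stand for weaker inhibition and lower numbers for stronger inhibition), compound 1 gives 4180 nM. Compound 2 reaches only a limit, > 50000 nM, namely (the limit of > 50000 nM in this assay, at which 1 of the 3 values shown sits). Compound 3 gives 450 nM, the lowest of the two numbers. The change from compound 2 to compound 1, (methyl in place of fluoro on an aromatic carbon), brought an at least 11-fold lower number from compound 2 to compound 1 (1.07 log units; beyond the scatter). The difference between the cores of compound 2 and compound 3 is not broken down here.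

Compound 4 `Cc1ccc2nc(Nc3ccnc(Nc4ccc(S(N)(=O)=O)cc4)n3)sc2c1` has not been measured. It differs from compound 3 by methyl in place of fluoro on an aromatic carbon. Going by the values given here, this is the same kind of change as the one from compound 2 to compound 1, not the same: here the place is a six-membered aromatic ring of carbon only, part of a fused system of two rings, whereas the earlier place was a six-membered aromatic ring with 2 nitrogen. The earlier step of an at least 11-fold lower number from compound 2 to compound 1 (1.07 log units; beyond the scatter) is therefore only a weak guide. In this assay compound 4 is expected to give about 400 nM, with a range from 120 nM to 1500 nM. That estimate means a 1.1-fold lower number from compound 3 to compound 4 (0.05 log units; within the scatter).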

Compound 4, half-maximal inhibitory concentration: 660 nM
The estimate for compound 4 lay 1.7-fold (0.22 log units) below the measured number; measured number inside the range.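

In this assay, methyl in place of fluoro on the fused system of two rings gives a 1.5-fold higher number from compound 3 to compound 4 (0.17 log units; within the scatter), and this step does not match the earlier one: the same change on two cores in this assay, an at least 11-fold lower number (1.07 log units; beyond the scatter) from compound 2 to compound 1 and a 1.5-fold higher number (0.17 log units; within the scatter) from compound 3 to compound 4, at least 17-fold (1.24 log units) apart, beyond the scatter of two such steps. This shows that, among these four compounds, the size of the step did not carry over from one core to the other, so the earlier result did not predict the new one. It does not show what sets the two steps apart, as the cores differ and the place of the change lies on a different ring in each pair.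

The compounds shown leave open how an amine or a methoxy group would behave at the place of the methyl in compound 4. They also leave open whether a third core would follow either step.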